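The source may report more compounds than this note shows. Statements on the series, on what has been measured and on what is new or still open speak of the compounds shown alone.

Measured compounds in this series:
compound 1 `Cc1ccc(S(=O)(=O)Nc2ccc3oc(-c4ccccc4)nc3c2)cc1` – > 100000 nM
compound 2 `O=S(=O)(Nc1ccc2oc(-c3ccccc3)nc2c1)c1ccc(F)c(C(F)(F)F)c1` – 69000 nM

In an assay on cells for inhibition of HSP60/HSP10 (Homo sapiens), with a stated time of 60 min (on this read-out higher numbers stand for weaker inhibition and lower numbers for stronger inhibition), compound 1 gives > 100000 nM, which is a limit of the assay and not a number, as recorded in the limit of > 100000 nM in this assay, at which 1 of the 2 values shown sits. In this assay compound 2 gives 69000 nM. Within the data shown here, no single-point step between the two measured compounds exists, so the two values show only that both sit at or near the weak end of the read-out.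

Compound 3 `O=S(=O)(Nc1ccc2oc(-c3ccccc3)nc2c1)c1ccc(O)cc1` differs from compound 1 by hydroxy in place of methyl on an aromatic carbon. With compound 1 standing at a limit, the step from it cannot be read in either direction from the numbers shown. The expected step of an at least 1.2-fold lower number from compound 1 to compound 3 (0.09 log units; that floor lies within the scatter) is therefore small, with the result likely to stay close to the limit or just under it. Compound 3 is estimated at 80000 nM, within a range of 20000 nM to 300000 nM, and a limit rather than a number is a real possibility.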

Compound 3, half-maximal inhibitory concentration: 88000 nM
Compound 3: the middle estimate sits 1.1-fold (0.04 log units) below what was measured; measured number inside the range.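

In this assay, hydroxy in place of methyl on an aromatic carbon, para to a large group, gives an at least 1.1-fold lower number from compound 1 to compound 3 (0.05 log units; that floor lies within the scatter). Among these compounds, this is the first step that can be read at all, but it has only a floor, and that floor does not establish a real gain from hydroxy at this position. For compound 1, the value > 100000 nM is a limit of the assay and not a number, so the full size of the step stays unknown: the limit of > 100000 nM in this assay, at which 1 of the 3 values shown sits.

On these data alone, whether an amine, a methoxy group or a carboxylic acid at this same position would give a number clearly lower than that of compound 3 remains open. Also open, as far as these compounds go, is whether any change elsewhere on the shared core would move the read-out away from its weak end.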